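Chloro for Methoxy: Expected Inhibition of Compound 4

The source may hold more compounds than are shown below. What is called first, only, known or untested is meant among the compounds shown, and "the series" means these compounds.

Compound 1 `Nc1ncc(-c2cccc(Cl)c2)c(-c2ccccc2)n1`: > 80%
Compound 2 `COc1ccc(-c2cnc(N)nc2-c2ccccc2)cc1`: 56%
Compound 3 `COc1ccc(-c2cnc(N)nc2-c2ccccc2)cc1OC`: > 80%

In an assay on CHO cells for displacement of a labelled ligand from adenosine receptor A1 (Homo sapiens), read by scintillation counting, with a stated time of 1 h, tested at 1 uM (on this read-out lower numbers stand for less inhibition and higher numbers for more inhibition at the one concentration tested (going by the name of the read-out)), compound 3 reaches only a limit of the assay, > 80%. Compound 1 likewise sits at a limit, > 80%. Compound 2 gives 56%, and the step of a number at least 24 percentage points higher from compound 2 to compound 3 (beyond the scatter) came with methoxy in place of hydrogen on an aromatic carbon; the reading is shaped by the limit of > 80% in this assay, at which 2 of the 3 values shown sit. Compound 4 `COc1ccc(-c2cnc(N)nc2-c2ccccc2)cc1Cl` differs from compound 3 by chloro in place of methoxy on an aromatic carbon. That measured step bears on it only loosely, as the methoxy it added is the group that now leaves, with a chloro entering, while the remaining methoxy stays. Compound 4 is expected to stay near the limit, a step that the limit leaves unreadable from compound 3 to compound 4. The estimate for compound 4 is 82%, between 65% and 95%.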

Compound 4, a percentage reported as inhibition, at one concentration (the size of the read-out at that concentration, not a potency): > 80%
Compound 4 ended at the assay's limit; the forecaster's own chance of this, stated with the estimate: 55%; the middle value lies beyond the limit too.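

In this assay compound 4 gives > 80%, which is a limit of the assay and not a number. Chloro in place of hydrogen at this place gives a number at least 24 percentage points higher from compound 2 to compound 4 (beyond the scatter), so the rise seen earlier is not confined to methoxy. The steps to compound 4 from compound 3 and from compound 1 cannot be read: the limit of > 80% in this assay, at which 3 of the 4 values shown sit.

From the compounds shown here alone, whether chloro or methoxy gives more inhibition at this place therefore stays open. Going by these compounds, it is also open whether an amine or a carboxylic acid on this aromatic carbon would bring a similar rise.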